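From propanoylamino to pyrrolidin-1-yl in compound 4

The source may report more compounds than this note shows. Statements on the series, on what has been measured and on what is new or still open speak of the compounds shown alone.

In a functional assay on HCT-116 cells (Homo sapiens) for inhibition (on this read-out higher numbers stand for weaker inhibition and lower numbers for stronger inhibition), compound 1 (`CCNC(=O)c1noc(-c2cc(C(C)C)c(O)cc2O)c1-c1cc(CNC(C)C)no1`) reads 109 nM and compound 2 (`C=CNCc1cc(-c2c(C(=O)NCC)noc2-c2cc(C(C)C)c(O)cc2O)on1`) reads 121 nM while compound 3 (`CCNC(=O)c1noc(-c2cc(C(C)C)c(O)cc2O)c1-c1cc(CNC(=O)CC)no1`) reads 78 nM on the same scale. Compound 3 stands within the scatter of both others, as shown by a 1.4-fold lower number from compound 1 to compound 3 (0.15 log units; within the scatter) and a 1.6-fold lower number from compound 2 to compound 3 (0.19 log units; within the scatter) at the same amine nitrogen, alongside a 1.1-fold higher number from compound 1 to compound 2 (0.05 log units; within the scatter) at that nitrogen.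

Compound 4 (`CCNC(=O)c1noc(-c2cc(C(C)C)c(O)cc2O)c1-c1cc(CN2CCCC2)no1`) carries the change (pyrrolidin-1-yl in place of propanoylamino on a saturated chain carbon bound to an aromatic carbon) from compound 3. None of the three measured steps closes a ring, so they bear on this change only indirectly, yet all stayed small. No step beyond the scatter is expected in this assay and no direction is favoured. The estimated step (a 1.3-fold higher number from compound 3 to compound 4 (0.11 log units; within the scatter)) is correspondingly small. Compound 4 is estimated at 100 nM (range 45 nM to 220 nM).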

Compound 4, half-maximal inhibitory concentration: 51 nM
Compound 4: middle estimate off by 2.0-fold (0.29 log units), on the high side; measured number inside the range.
By their numbers in this assay, from the lowest: compounds 4, 3, 1 and 2 (each within the scatter of the next, the first and the last beyond it).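

In this assay, among the compounds shown here, the pyrrolidin-1-yl ring on this saturated chain carbon gives the first steps beyond the scatter: a 2.4-fold lower number from compound 2 to compound 4 (0.38 log units; beyond the scatter) and a 2.1-fold lower number from compound 1 to compound 4 (0.33 log units; beyond the scatter) are both modest. Against propanoylamino, a 1.5-fold lower number from compound 3 to compound 4 (0.18 log units; within the scatter) stays within the scatter, so compound 3 and compound 4 cannot be ordered. No measurement on hand accounts for these steps.

On these data alone, whether the closed ring itself or the missing hydrogen on the nitrogen matters stays open. An open dimethylamino group, or a piperidin-1-yl or morpholin-4-yl ring, would bear on that.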